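The source may hold more compounds than are shown below. What is called first, only, known or untested is meant among the compounds shown, and "the series" means these compounds.

Series notes. Compound 1 `COc1ccc(OCCCCCN2CCCC(COC(=O)c3ccccc3N3C(=O)CC(C)C3=O)C2)cc1`, compound 2 `CC1(C)CC(=O)N(c2ccccc2C(=O)OCC2CCCN(CCCc3ccccc3)C2)C1=O` and compound 3 `O=C(Nc1ccccn1)c1ccccc1-c1ccccc1` have been run in an in vitro functional assay on HEK ts201 cells for antagonist activity at Neuronal acetylcholine receptor; alpha4/beta2 (Homo sapiens), read by fluorescence and calcium flux; a higher number here means a weaker inhibitor, a lower number a stronger inhibitor. Compound 1 gives 14500 nM, the highest of the three numbers. Compound 3 gives 13600 nM, within the scatter of compound 1. Compound 2 gives 4900 nM, a lower number beyond the scatter from compound 1. Compound 4 `CC1CC(=O)N(c2ccccc2C(=O)OCC2CCCN(CCCCCOc3ccccc3)C2)C1=O` has not yet been measured in this assay. It differs from compound 1 in one place: hydrogen in place of methoxy on an aromatic carbon. Going by the values given here, no measured pair shares this change, so no measured step guides the expectation, and compound 1 and compound 2 differ in several places at once. For compound 4 the step of a 1.5-fold lower number from compound 1 to compound 4 (0.16 log units; within the scatter) is expected to be small, toward a lower number, hardly beyond the scatter. Compound 4 is estimated at 10000 nM, with a range from 4000 nM to 25000 nM.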

Compound 4, half-maximal inhibitory concentration: 17000 nM
Compound 4: middle estimate off by 1.7-fold (0.23 log units), on the low side, within the range that was stated.
By their numbers in this assay, from the lowest: compound 2; then compounds 3, 1 and 4 (each within the scatter of the next).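

In this assay, going from 4-methoxyphenoxy to phenoxy gives a 1.2-fold higher number from compound 1 to compound 4 (0.07 log units; within the scatter), so on this aromatic carbon, para to a large group, hydrogen in place of methoxy leaves no difference that can be told from the scatter. The methoxy is therefore not required to keep inhibition at this level in this series. No supporting data are available to explain this result. On these data alone, whether an amine or a carboxylic acid at this position would shift the number remains open, as does the outcome with a longer chain carrying the phenoxy group.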